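Swapping tert-butyl for 3,5-dimethoxyphenyl on the acyl carbonyl

The compounds below may be only part of what the source reports. "The series", "measured", "known", "first", "only" and "open" are said of these compounds alone.

Compound 1 `CCCCCCCCCCCCCCNC(=O)[C@H](CO)NC(=O)C1CCCCC1` gives 11500 nM
Compound 2 `CCCCCCCCCCCCCCNC(=O)[C@H](CO)NC(=O)C(C)(C)C` gives 6100 nM

Both values come from a functional assay on MDA-MB-231 cells (Homo sapiens) for inhibition, read by microscopy and colony formation, with a stated time of 10 days (a higher number here means a weaker inhibitor, a lower number a stronger inhibitor), and on these numbers compound 2 stands level with compound 1, since the two lie within the scatter of each other. The next compound, compound 3 `CCCCCCCCCCCCCCNC(=O)[C@H](CO)NC(=O)c1cc(OC)cc(OC)c1`, keeps the shared core and alters only the group on the carbonyl carbon that the first two compounds also vary. The change is 3,5-dimethoxyphenyl in place of tert-butyl on a carbonyl carbon, so 3,5-dimethoxyphenyl stands in place of tert-butyl.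

Among the compounds with values here, one measured step bears on this change: a 1.9-fold lower number from compound 1 to compound 2 (0.28 log units; within the scatter). It is the exchange of cyclohexyl for tert-butyl at this same place, and it gives no shift that can be told from the scatter. Within the data shown here, no measured compound carries an aromatic ring here, so the evidence for the new group is thin and the range must stay wide. The expected change is a 1.3-fold higher number from compound 2 to compound 3 (0.12 log units; within the scatter), which means no estimated shift beyond the scatter in either direction. For compound 3 the estimated value is 8000 nM, with an expected range from 3000 nM to 20000 nM.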

Compound 3, half-maximal inhibitory concentration: 6600 nM
For compound 3 the middle estimate is 1.2-fold (0.08 log units) above the measured one; low and high end bracket the measured number.
By their numbers in this assay, from the lowest: compounds 2, 3 and 1 (each within the scatter of the next).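

Within the data shown here, with 3,5-dimethoxyphenyl, an aromatic ring stands on this carbonyl carbon for the first time, and in this assay the exchange gives a 1.1-fold higher number from compound 2 to compound 3 (0.03 log units; within the scatter) against tert-butyl and a 1.7-fold lower number from compound 1 to compound 3 (0.24 log units; within the scatter) against cyclohexyl. Neither step can be told from the scatter, so cyclohexyl, tert-butyl and 3,5-dimethoxyphenyl all stand level here, although the entering group adds a six-membered aromatic ring of carbon only and two hydrogen-bond acceptors, neither of which tert-butyl has. No other measurement is at hand that could account for this flat result.

These three compounds leave open whether a group carrying an amine or a carboxylic acid on this carbonyl carbon would move the number beyond the scatter, since all three groups shown have no net charge. They also leave open whether a plain phenyl ring without its two methoxy groups would stand level with 3,5-dimethoxyphenyl, or whether the methoxy groups and the ring make separate contributions that happen to cancel in this assay.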